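Sulfonyl aryl swap at the sulfonamide in a serotonin-receptor series

A few compounds are considered here, and "the series" means these few. Any claim that something is new, unique, unknown or untested is made for them only; others in the source may bear on it.

Compound 2 `COc1ccc(S(=O)(=O)NCCN2CCC(CCC(=O)c3cc(Cl)c(N)cc3OC)CC2)cc1OC` gives the lower of the two numbers shown, 3% in an assay on HEK293 cells for displacement of a labelled ligand from 5-hydroxytryptamine receptor 6 (Homo sapiens), with a stated time of 60 min, tested at 0.01 uM, in the presence of a further agent that is not named here; a higher number here means a stronger effect of the compound at the concentration tested, a lower number a weaker effect. Among the measured compounds shown here, compound 1 `COc1cc(N)c(Cl)cc1C(=O)CCC1CCN(CCNS(=O)(=O)c2cc(Br)ccc2Br)CC1` gives 16%, and the one measured step, a number 13 percentage points lower from compound 1 to compound 2 (beyond the scatter), is the only guide here. Compound 3 `COc1cc(N)c(Cl)cc1C(=O)CCC1CCN(CCNS(=O)(=O)c2ccc(N)c(Br)c2)CC1` differs from compound 2 by 4-amino-3-bromophenyl in place of 3,4-dimethoxyphenyl on a sulfonyl sulfur, again at the sulfonyl position where that step was seen. Since a bromine-bearing aryl returns, a modest rise is expected, a number 9 percentage points higher from compound 2 to compound 3 (within the scatter), though the pattern rests on a single pair. Compound 3 is therefore estimated at 12%, with a range from 0% to 28%.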

Compound 3, a percentage reported as inhibition, at one concentration (the size of the read-out at that concentration, not a potency): 39%
Estimate against measurement, compound 3: 27 percentage points below; measured number above the stated range.
By their numbers in this assay, from the lowest: compound 2; then compound 1; then compound 3.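

On a sulfonyl sulfur, the change to 4-amino-3-bromophenyl gives a number 36 percentage points higher from compound 2 to compound 3 (beyond the scatter) in this assay, so this position can raise the number as well as lower it. Bromine on the aryl does not alone settle the outcome, since replacing 2,5-dibromophenyl gives a number 23 percentage points higher from compound 1 to compound 3 (beyond the scatter) even though both aryls carry bromine. Nothing available explains this rise.

Still open, going by these compounds, is whether the amine or the bromine goes with the higher number, a question that 4-aminophenyl and 3-bromophenyl on the sulfonyl sulfur would separate.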